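Replacing a ring side group on compound 3

A few compounds are considered here, and "the series" means these few. Any claim that something is new, unique, unknown or untested is made for them only; others in the source may bear on it.

compound 1 `Cc1cc(=O)c2c(O)cc(OCc3ccc(Br)cc3)c([C@H]3CCN(C)C[C@H]3O)c2o1` gives 13%
compound 2 `Cc1cc(=O)c2c(O)cc(OCc3ccccc3Br)c([C@H]3CCN(C)C[C@H]3O)c2o1` gives 35%
compound 3 `Cc1cc(=O)c2c(O)c(CN3CCCC3CO)c(O)c([C@H]3CCN(C)C[C@H]3O)c2o1` gives 19%

All three values come from a functional assay on Caco-2 cells (Homo sapiens) for inhibition, read by MTT assay, with a stated time of 48 h, tested at 10 uM; on this read-out lower numbers stand for less inhibition of growth and higher numbers for more inhibition of growth at the one concentration tested. Compound 3, at 19%, lies within the usual scatter of compound 1, so those two cannot be told apart. Compound 2 lies beyond the scatter from both.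

The next molecule, compound 4 `Cc1cc(=O)c2c(O)c(CN3CCCCC3)c(O)c([C@H]3CCN(C)C[C@H]3O)c2o1`, differs from compound 3 in one place, a saturated chain carbon bound to an aromatic carbon. The change is piperidin-1-yl in place of 2-(hydroxymethyl)pyrrolidin-1-yl on a saturated chain carbon bound to an aromatic carbon.

Among the compounds with values here, no measured pair makes this swap, so the evidence is thin. Within the data shown here, the only measured step is a number 22 percentage points higher from compound 1 to compound 2 (beyond the scatter). It sits elsewhere on the molecule, on a saturated chain carbon bound to an oxygen on an aromatic ring. It shows that one side-group change can move this read-out beyond the scatter, but it gives no direction for the swap in compound 4. A step of that modest size cannot be ruled out either way, yet nothing measured points to one. In this assay, then, no step beyond the scatter is expected.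

The expected change is a number 5 percentage points higher from compound 3 to compound 4 (within the scatter). For compound 4 the estimated value is 24%, with an expected range from 8% to 45%.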

Compound 4, percent growth inhibition at one concentration: 22%
Compound 4: the middle estimate sits 2 percentage points above what was measured, and the stated range covers the measured number.
By their numbers in this assay, from the lowest: compounds 1, 3 and 4 (each within the scatter of the next); then compound 2.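

In this assay, piperidin-1-yl in place of 2-(hydroxymethyl)pyrrolidin-1-yl on a saturated chain carbon bound to an aromatic carbon gives a number 3 percentage points higher from compound 3 to compound 4 (within the scatter) and so leaves the read-out inside its usual scatter. Within the data shown here, this single swap alters two things at once: a five-membered ring becomes a six-membered ring, and the hydroxymethyl arm with its oxygen and hydrogen-bond donor is gone, yet together these alterations produce no step that can be told apart from repeat measurement at this one concentration. Nothing available explains this outcome, and no separate measurement bears on it.

On these data alone, what remains open is how each of the two alterations acts alone, since opposing effects that cancel cannot be distinguished from two alterations that both do little. Plain pyrrolidin-1-yl would separate ring size from the hydroxymethyl arm, while morpholin-4-yl or an open-chain amine such as dimethylamino would show whether any other group at this place moves the number beyond the scatter.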